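Fluoro to methyl swap on the aromatic ring: compound 4

A few compounds are considered here, and "the series" means these few. Any claim that something is new, unique, unknown or untested is made for them only; others in the source may bear on it.

Measured in an assay on isolated protein for inhibition of Myeloperoxidase (Homo sapiens), read by fluorescence, with stated times of 10 min, 30 s and 5 min; on this read-out lower numbers stand for stronger inhibition and higher numbers for weaker inhibition:
compound 1 `CCNc1nc(OCc2ccccc2)c2nn[nH]c2n1` gives 2900 nM
compound 2 `Nc1nc(OCCc2ccccc2)c2nn[nH]c2n1` gives 630 nM
compound 3 `Nc1nc(OCc2ccccc2F)c2nn[nH]c2n1` gives 78 nM

Compound 3 shows the lowest number of the three in this assay; the numbers for compound 2 and compound 1 lie beyond the scatter above it, so compound 3 stands as the most potent member measured. The unmeasured compound 4 `Cc1ccccc1COc1nc(N)nc2[nH]nnc12` differs from compound 3 in one place: methyl in place of fluoro on an aromatic carbon. Going by the values given here, no measured pair isolates such a swap, so the size of the step rests on the change alone. A small step, likely within the scatter and if anything toward a weaker number, is expected from compound 3 to compound 4, a 1.5-fold higher number from compound 3 to compound 4 (0.19 log units; within the scatter). Compound 4 is estimated at 120 nM in this assay, with a range from 40 nM to 400 nM.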

Compound 4, half-maximal inhibitory concentration: 470 nM
Compound 4: the middle estimate sits 3.9-fold (0.59 log units) below what was measured; the whole stated range lies below it.
By their numbers in this assay, from the lowest: compound 3; then compounds 4 and 2 (each within the scatter of the next); then compound 1.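

In this assay the aromatic carbon ortho to a large group responds to a one-atom exchange: methyl in place of fluoro gives a 6.0-fold higher number from compound 3 to compound 4 (0.78 log units; beyond the scatter) with no change in the count of heavy atoms, donors or acceptors. This is the series' first step that isolates one place, and it shows that the group on this carbon alone can move the number beyond the scatter. Nothing at hand accounts for the size of this step.

Still open, going by these compounds, is how hydrogen, chloro or methoxy on this carbon would compare with fluoro and methyl. Also open, on these data alone, is whether fluoro raises potency or methyl lowers it.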